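The source may hold more compounds than are shown below. What is called first, only, known or untested is meant among the compounds shown, and "the series" means these compounds.

Compound 1, `Cc1ccc2cccc(NS(=O)(=O)c3ccccc3[N+](=O)[O-])c2n1`, in an assay on OCI-Ly3 cells for activation of NF-kappa-B inhibitor alpha (Homo sapiens), read by a luciferase reporter; on this read-out higher numbers stand for larger maximal responses and lower numbers for smaller maximal responses: 200%
Compound 2, `O=[N+]([O-])c1cc(C(F)(F)F)ccc1S(=O)(=O)Nc1cccc2cccnc12`, in this assay: 200%

In this assay compound 2 gives 200%, and it stands level with compound 1 at the digits shown: the two values lie within the scatter of each other, so neither can be placed above the other. Among the compounds with values here, compound 2 is the nearest neighbour of compound 1 among the measured compounds, yet the two differ at more than one place, and no single-change step between measured compounds is available.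

Compound 3, `Cc1ccc2cccc(NS(=O)(=O)c3ccc(C(F)(F)F)cc3[N+](=O)[O-])c2n1`, differs from compound 2 in one place: methyl in place of hydrogen on an aromatic carbon. Nothing measured isolates this change. What the two measured values do show is that compound 1, which carries such a methyl, and compound 2, which does not, reach the same maximal response in this assay. On that basis the step of a number 5 percentage points lower from compound 2 to compound 3 (within the scatter) is expected to be small, with no direction beyond the scatter. For compound 3 the maximal response in this assay is therefore estimated at 195%, within a range from 160% to 225%.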

Compound 3, largest response reached (reported as efficacy), in percent of the reference or control that the assay uses: 50%
Beside the measured number, compound 3's estimate is 145 percentage points above it; measured number outside the range, below it.
By their numbers in this assay, from the lowest: compound 3; then compounds 1 and 2 (each within the scatter of the next).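

In this assay, the methyl on the aromatic carbon next to the ring nitrogen proves far from neutral when the trifluoromethyl is present, with a number 150 percentage points lower from compound 2 to compound 3 (beyond the scatter). The trifluoromethyl, with the methyl present, likewise gives a number 150 percentage points lower from compound 1 to compound 3 (beyond the scatter), so among these compounds the low maximal response appears only where both groups occur together, which the level values of compound 1 and compound 2 could not reveal on their own. No available evidence bears on the reason for this drop.

Going by these compounds, whether either group changes the response on a core that has hydrogen at both places remains open, so the separate contribution of each group cannot be stated. On these data alone, it also remains open whether an ethyl group or a methoxy group on the same aromatic carbon would give the same low response, and whether a chlorine atom or a nitrile in place of the trifluoromethyl would do so alongside the methyl.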